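Weak Cytotoxicity in a Small Lactone Series

The source may report more compounds than this note shows. Statements on the series, on what has been measured and on what is new or still open speak of the compounds shown alone.

Measured compounds:
Compound 1, `CC(=O)O[C@@H]1OC(=O)[C@](OC(C)=O)(C(C)=O)[C@@H]1C`: > 50000 nM in a functional assay on DA-3 cells for cytotoxicity against DA-3 cell line (Mus musculus), read by MTT assay; a higher number here means a weaker inhibitor, a lower number a stronger inhibitor
Compound 2, `CC(=O)O[C@@H]1OC(=O)[C@@](Cc2ccccc2)(C(C)=O)[C@@H]1C`: 44000 nM

Compound 1 gives > 50000 nM in this assay, which is a limit of the assay rather than a number. Going by the values given here, compound 2 gives 44000 nM, and this is the only actual number among the two values shown. The other value, that of compound 1, is a limit, as summed up in the limit of > 50000 nM in this assay, at which 1 of the 2 values shown sits. On the numbers shown, compound 2 therefore stands alone, with nothing to rank it against.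

Compound 3, `CC(=O)O[C@@H]1OC(=O)[C@@](OC(C)=O)(C(C)=O)[C@@H]1C`, has not yet been measured. It differs from compound 2 in one place: acetoxy in place of benzyl on a saturated ring carbon. Compound 3 carries the same groups as compound 1 but differs in their spatial arrangement at the substituted ring carbons.

Among the compounds with values here, no step between measured compounds exists to set the size of this change. Both measured values sit at the weak end, so compound 3 is expected to be weak as well, with a step from compound 2 that is expected to be small, a 1.4-fold higher number from compound 2 to compound 3 (0.13 log units; within the scatter). Compound 3 is estimated at 60000 nM, with a range from 25000 nM to 150000 nM, and a limit rather than a number is quite likely.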

Compound 3, half-maximal inhibitory concentration: > 50000 nM
Compound 3 gave a limit, no number; the forecaster's own chance of this, stated with the estimate: 60%; the middle value lies beyond the limit too.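

Setting acetoxy in place of benzyl on this saturated ring carbon gives an at least 1.1-fold higher number from compound 2 to compound 3 (0.05 log units; that floor lies within the scatter) in this assay, so the swap brings no lower number, and how much higher the true value lies cannot be told. The series now sits mostly at the edge of what the assay can report, and this edge is a limit rather than a number: the limit of > 50000 nM in this assay, at which 2 of the 3 values shown sit. The step between compound 1 and compound 3 cannot be read, so this pair shows no measurable effect of the drawn arrangement, although it is the closest comparison in the set: the fact that compounds 1 and 3 differ only in the configuration as drawn

Going by these compounds, how far past the limit compound 1 and compound 3 truly lie remains open, and so does whether their drawn arrangements differ at all in this assay. Also open, on these data alone, is whether an amine, a carboxylic acid or a longer chain on this ring carbon would bring the number down from the weak end where all three compounds sit.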